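This account rests on a few compounds, and the source may have more. Where it says the series, first, only, none or still open, it means among the compounds named here.

Measured so far in a functional assay on BT-549 cells (Homo sapiens) for cytotoxicity, read by MTT assay, with a stated time of 48 h; on this read-out higher numbers stand for weaker inhibition and lower numbers for stronger inhibition:

Compound 1 `CCn1c(/C=C2/C(=O)Nc3ccc(F)cc32)nc2ccccc21`: > 50000 nM, a limit of the assay and not a number
Compound 2 `CC(C)n1c(/C=C2/C(=O)Nc3ccc(Cl)cc32)nc2ccccc21`: 35100 nM

Within the data shown here, compound 2 holds the only exact number so far, and the one other result is a limit. That leaves very little to build on. The next compound to place on this scale is compound 3 `CCn1c(/C=C2/C(=O)Nc3ccc(Cl)cc32)nc2ccccc21`. It comes from compound 2 through one small structural change, (hydrogen in place of methyl on a saturated chain carbon bound to an aromatic nitrogen and a saturated chain carbon). In words, hydrogen takes the place of methyl on a saturated chain carbon bound to an aromatic nitrogen and a saturated chain carbon, so isopropyl becomes ethyl.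

Among the measured compounds shown here, no measured pair shows this change on its own, so the expectation rests on compound 2 at 35100 nM. A step within the usual scatter is expected in this assay, with a slight lean toward weaker inhibition. The assay may also report only a limit for the new compound. The expected change is a 1.1-fold higher number from compound 2 to compound 3 (0.06 log units; within the scatter). Compound 3 is estimated at 40000 nM, with an expected range of 20000 nM to 70000 nM.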

Compound 3, half-maximal inhibitory concentration: > 50000 nM
Compound 3 gave a limit, no number; the forecaster's own chance of this, stated with the estimate: 35%; middle value at least 1.2-fold (0.09 log units) away from the limit.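

Compound 3 gives the first direct view of the change from isopropyl to ethyl in this assay, and the step is an at least 1.4-fold higher number from compound 2 to compound 3 (0.15 log units; that floor lies within the scatter). The result for compound 3, > 50000 nM, is a limit of the assay and not a number. This means the step has only a floor, so it does not establish that the ethyl compound is truly weaker than the isopropyl compound, and the step for chloro in place of fluoro cannot be read at all, with the same limit standing in the way of both readings: the limit of > 50000 nM in this assay, at which 2 of the 3 values shown sit.

As far as these compounds go, only isopropyl and ethyl appear at this place, so it remains open whether a longer chain, a benzyl group or a chain ending in an amine would bring the number clearly down. Among these compounds, compound 2 is also the only compound with an exact number, which leaves open how far the result moves when its chloro is replaced by another group, such as methoxy or nitrile, while the isopropyl stays in place.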